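This account rests on a few compounds, and the source may have more. Where it says the series, first, only, none or still open, it means among the compounds named here.

Series notes. Compound 1 `Oc1ccc(-c2cc(-c3cccnc3)nc(-c3ccccc3Cl)c2)cc1` carries no number in an ADME assay on HEK293 cells (Homo sapiens) for cytotoxicity, read by CCK-8 assay and cell counting, with a stated time of 2 days; a lower number here means a stronger inhibitor, a higher number a weaker inhibitor; its entry reads "not determined" (no result reported). Two other members give a sense of the range: compound 2 `Oc1cccc(-c2cc(-c3ccc(Cl)cc3)nc(-c3cccs3)c2)c1` gives 11800 nM in this assay, and compound 3 `Oc1cccc(-c2cc(-c3ccc(Cl)cc3)nc(-c3ccco3)c2)c1` gives 8190 nM. For the measured compounds named here, the only step between measured compounds, a 1.4-fold lower number from compound 2 to compound 3 (0.16 log units; within the scatter), concerns furan-2-yl in place of thiophen-2-yl and does not touch the change considered here.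

Compound 4 `Oc1ccc(-c2cc(-c3cccs3)nc(-c3ccccc3Cl)c2)cc1` differs from compound 1 by thiophen-2-yl in place of pyridin-3-yl on an aromatic carbon. Going by the values given here, no measured step bears on this exchange, so the expectation rests on the general level seen for compound 2 and compound 3 alone, with no direction assumed. Compound 4 is therefore expected to give about 10000 nM in this assay, within roughly 3500 nM to 30000 nM.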

Compound 4, half-maximal inhibitory concentration: 5220 nM
Estimate against measurement, compound 4: 1.9-fold (0.28 log units) above, within the range that was stated.
By their numbers in this assay, from the lowest: compounds 4, 3 and 2 (each within the scatter of the next, the first and the last beyond it).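

For the compounds shown here, compound 1 reads "not determined" (no result reported) in this assay, so no step to compound 4 can be read. The compounds shown leave open what thiophen-2-yl in place of pyridin-3-yl does to this number. No evidence bears on the result.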